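The compounds below may be only part of what the source reports. "The series", "measured", "known", "first", "only" and "open" are said of these compounds alone.

Measured in an ADME assay on L6 cells (Rattus norvegicus) for cytotoxicity, read by fluorescence and resazurin assay, with a stated time of 72 h; on this read-out higher numbers stand for an effect only at larger amounts of compound and lower numbers for an effect already at smaller amounts:
compound 1, `Cc1cncc(-c2ccc3[nH]c(=O)nc(-c4ccccc4)c3c2)c1`: > 50000 nM, a limit of the assay, not a number.
compound 2, `O=c1nc(-c2ccccc2)c2cc(-c3ccccc3)ccc2[nH]1`: > 50000 nM, likewise a limit.
compound 3, `O=c1nc(-c2ccccc2)c2cc(-c3cccc(F)c3)ccc2[nH]1`: 23000 nM.

Among the measured compounds shown here, compound 3 holds the only read number in the set; the other two values sit at the limit (the limit of > 50000 nM in this assay, at which 2 of the 3 values shown sit). Compound 4, `CNC(=O)c1cccc(-c2ccc3[nH]c(=O)nc(-c4ccccc4)c3c2)c1`, carries methylcarbamoyl in place of fluoro on an aromatic carbon. For the measured compounds named here, the one measured step that touches the fluoro is an at least 2.1-fold lower number from compound 2 to compound 3 (0.33 log units; beyond the scatter); taking the fluoro away again is therefore expected to undo that move, while the methylcarbamoyl itself has no measured counterpart here. The steps of an at least 2.1-fold lower number from compound 1 to compound 3 (0.33 log units; beyond the scatter) and a step that the two limits leave unreadable from compound 1 to compound 2 concern a ring swap and bear less. Compound 4 is thus estimated at 45000 nM, range 15000 nM to 200000 nM, a step of a 2.0-fold higher number from compound 3 to compound 4 (0.29 log units; within the scatter), with a fair chance that only a limit is reported.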

Compound 4, half-maximal effective concentration: > 50000 nM
Compound 4 gave a limit, no number (the forecaster's own chance of this, stated with the estimate: 60%); middle value at least 1.1-fold (0.04 log units) from the limit.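

In this assay, methylcarbamoyl in place of fluoro on this aromatic carbon, meta to a large group, gives an at least 2.1-fold higher number from compound 3 to compound 4 (0.33 log units; beyond the scatter). Among the compounds shown here, compound 4 gives > 50000 nM, a limit, so the fluoro-bearing compound 3 remains the only one with a read number, and a second substituent at this position, after hydrogen, ends at the limit: the limit of > 50000 nM in this assay, at which 3 of the 4 values shown sit. The step between compound 2 and compound 4 cannot be read, as both values are limits.

From the compounds shown here alone, whether a carboxylic acid or an amine at this position would give a read number stays open. So does any ordering of compound 1, compound 2 and compound 4.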